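Fluoro in place of methyl: compound 3 to compound 4

The compounds below may be only part of what the source reports. "The series", "measured", "known", "first", "only" and "open" are said of these compounds alone.

In a functional assay on L1210 cells (Mus musculus) for antiproliferative activity, read by cell counting, with a stated time of 2 days (a lower number here means a stronger inhibitor, a higher number a weaker inhibitor), compound 3 `COc1cc(C(=O)c2sc(Nc3ccc(C)cc3)nc2N)cc(OC)c1OC` gives 31 nM, the lowest of the two numbers shown. Compound 2 `COc1cccc(Nc2nc(N)c(C(=O)c3ccccc3)s2)c1` gives 8200 nM, a gap beyond the scatter. For compound 1 `COc1ccc(C(=O)c2sc(Nc3ccc(F)cc3)nc2N)cc1` the result is a limit of the assay, not a number: > 10000 nM. This is the limit of > 10000 nM in this assay, at which 1 of the 3 values shown sits. Compound 4 `COc1cc(C(=O)c2sc(Nc3ccc(F)cc3)nc2N)cc(OC)c1OC` differs from compound 3 in one place: fluoro in place of methyl on an aromatic carbon. Within the data shown here, no step between measured compounds is available, so the size of this change rests on the structural change alone. The step of a 1.9-fold higher number from compound 3 to compound 4 (0.29 log units; within the scatter) is expected to be small, within the scatter or slightly toward a higher number. Compound 4 is estimated at 60 nM, with a range from 15 nM to 300 nM.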

Compound 4, half-maximal inhibitory concentration: 900 nM
Estimate against measurement, compound 4: 15-fold (1.18 log units) below, outside the stated range (above it).
By their numbers in this assay, from the lowest: compound 3; then compound 4; then compound 2. At a limit, above all of these: compound 1.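

Fluoro in place of methyl on this aromatic carbon is not a neutral exchange: in this assay the change gives a 29-fold higher number from compound 3 to compound 4 (1.46 log units; beyond the scatter) and is the first one-place step available in the series. The number at this position therefore moves well beyond the scatter, although the two groups match in heavy-atom count and neither carries a hydrogen-bond donor or acceptor. Nothing shown accounts for the size of this step.

Open, as far as these compounds go, is where chloro, ethyl, methoxy or an amine on this carbon would fall relative to compound 3 and compound 4. That leaves unsettled whether methyl is specifically favoured or fluoro specifically disfavoured.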